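A few compounds are considered here, and "the series" means these few. Any claim that something is new, unique, unknown or untested is made for them only; others in the source may bear on it.

Compound 1 `Oc1cccc(-c2cc(-c3ccccc3F)cc(-c3ccccc3O)n2)c1` — in a functional assay on HCT-15 cells (Homo sapiens) for inhibition (on this read-out higher numbers stand for weaker inhibition and lower numbers for stronger inhibition), compound 1 gives 8470 nM.
Compound 2 `Oc1cccc(-c2cc(-c3ccc(F)cc3)cc(-c3ccccc3O)n2)c1` — for compound 2 this assay reports only a limit, > 50000 nM.
Compound 3 `Oc1ccccc1-c1cc(-c2cccc(C(F)(F)F)c2)cc(-c2ccccc2O)n1` — for compound 3 this assay reports only a limit, > 50000 nM.

Compound 3 thus stands at the limit of this assay and not at a measured number (the limit of > 50000 nM in this assay, at which 2 of the 3 values shown sit).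

Compound 4 `Oc1cccc(-c2cc(-c3cccc(C(F)(F)F)c3)cc(-c3ccccc3O)n2)c1` differs from compound 3 by 3-hydroxyphenyl in place of 2-hydroxyphenyl on an aromatic carbon. Within the data shown here, the only measured step, an at least 5.9-fold higher number from compound 1 to compound 2 (0.77 log units; beyond the scatter), concerns the fluorophenyl group rather than this change and gives no direct guide; compounds 1 and 2, both carrying 3-hydroxyphenyl, show that this group by itself does not secure a measurable number. For compound 4 a step of a number no higher from compound 3 to compound 4 (the limit leaves the size open) is therefore expected. Compound 4 is estimated at 50000 nM (range 12000 nM to 200000 nM), most likely reported again only as a limit.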

Compound 4, half-maximal inhibitory concentration: 6460 nM
Compound 4: middle estimate off by 7.7-fold (0.89 log units), on the high side; measured number below the stated range.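

With the 3-(trifluoromethyl)phenyl group held constant, 3-hydroxyphenyl in place of 2-hydroxyphenyl next to the ring nitrogen gives an at least 7.7-fold lower number from compound 3 to compound 4 (0.88 log units; beyond the scatter) in this assay, so this position responds to where the hydroxyl sits. With 3-hydroxyphenyl held constant, the other aryl group also counts: 3-(trifluoromethyl)phenyl in place of 4-fluorophenyl gives an at least 7.7-fold lower number from compound 2 to compound 4 (0.88 log units; beyond the scatter), whereas in place of 2-fluorophenyl it gives a 1.3-fold lower number from compound 1 to compound 4 (0.12 log units; within the scatter).

From the compounds shown here alone, the full size of the first two steps stays open, since each starts from a limit. Also open, going by these compounds, is whether an amine or a carboxylic acid in place of that hydroxyl would hold the number.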